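Swapping the Amide Substituent on a 5-HT1F Ligand

A few compounds are considered here, and "the series" means these few. Any claim that something is new, unique, unknown or untested is made for them only; others in the source may bear on it.

Compounds measured so far:
compound 1, `CN1CCC(c2c[nH]c3ccc(NC(=O)C4CCCCC4)nc23)CC1`, 20 nM;
compound 2, `CN1CCC(c2c[nH]c3ccc(NC(=O)c4ccc(C#N)cc4)nc23)CC1`, 7.2 nM;
compound 3, `CN1CCC(c2c[nH]c3ccc(NC(=O)c4cccs4)nc23)CC1`, 7.1 nM.

All three share one core and differ only in the group attached to the carbonyl carbon of the amide. In an assay for binding affinity to 5-hydroxytryptamine receptor 1F (Homo sapiens), read by radioligand binding (on this read-out lower numbers stand for stronger inhibition and higher numbers for weaker inhibition), compound 3 gives 7.1 nM, the lowest number of the three, though its gap to compound 2 is within the scatter, so the two cannot be ordered. Compound 1, with cyclohexyl on the carbonyl carbon, stands apart: a 2.8-fold lower number from compound 1 to compound 3 (0.45 log units; beyond the scatter), and a 2.8-fold lower number from compound 1 to compound 2 (0.44 log units; beyond the scatter). Between the two aromatic groups there is nothing to separate: a 1.0-fold lower number from compound 2 to compound 3 (0.01 log units; within the scatter).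

The next compound, compound 4, `CN1CCC(c2c[nH]c3ccc(NC(=O)C(C)(C)C)nc23)CC1`, differs from compound 3 by tert-butyl in place of thiophen-2-yl on a carbonyl carbon. The step that bears on this is the one from the aliphatic cyclohexyl of compound 1 to the aromatic groups of compounds 2 and 3, which was modest but beyond the scatter. Moving back to a saturated, non-aromatic group is therefore expected to raise the number in this assay, by about a 3.5-fold higher number from compound 3 to compound 4 (0.55 log units; beyond the scatter). Compound 4 is expected to give 25 nM, within a range of 8 nM to 80 nM.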

Compound 4, inhibition constant: 62 nM
The estimate for compound 4 lay 2.5-fold (0.39 log units) below the measured number, and the stated range covers the measured number.
By their numbers in this assay, from the lowest: compounds 3 and 2 (each within the scatter of the next); then compound 1; then compound 4.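

Of the groups shown on this carbonyl carbon, tert-butyl gives the highest number in this assay, and leaving the aromatic groups for it is a much larger step than any seen among the earlier compounds: an 8.7-fold higher number from compound 3 to compound 4 (0.94 log units; beyond the scatter) and an 8.6-fold higher number from compound 2 to compound 4 (0.94 log units; beyond the scatter). The two groups without an aromatic ring also separate from each other, as a 3.1-fold higher number from compound 1 to compound 4 (0.49 log units; beyond the scatter) shows, so the position responds to which saturated group it carries and not only to whether an aromatic ring is present. All four compounds fit one ordering, with the thiophen-2-yl and 4-cyanophenyl amides together at the low end, then cyclohexyl, then tert-butyl, but nothing given here explains that ordering or the size of the steps.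

The four compounds leave open whether the higher number of compound 4 goes with the absence of a ring or with the branched tert-butyl group itself, and a straight butyl chain or a cyclopentyl ring on the same carbonyl carbon would help separate the two. Going by these compounds, it also remains open how an unsubstituted phenyl group would compare with the thiophen-2-yl and 4-cyanophenyl groups, and whether the nitrile of compound 2 contributes anything to its number.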